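Halogen swap on the aryl ring: estimating compound 4

The compounds below may be only part of what the source reports. "The series", "measured", "known", "first", "only" and "open" are said of these compounds alone.

Measured in an ADME assay on HT-29 cells (Homo sapiens) for cytotoxicity, read by MTT assay, with a stated time of 72 h; on this read-out higher numbers stand for weaker inhibition and lower numbers for stronger inhibition:
- compound 1 `C=CC(=O)Nc1cc(Nc2ncc3ncn(-c4ccc(C(C)C)cc4)c3n2)c(OC)cc1N(C)CCN(C)C` gives 15300 nM
- compound 2 `C=CC(=O)Nc1cc(Nc2ncc3ncn(-c4ccc(F)cc4)c3n2)c(OC)cc1N(C)CCN(C)C` gives 12000 nM
- compound 3 `C=CC(=O)Nc1cc(Nc2ncc3ncn(-c4ccc(Br)cc4)c3n2)c(OC)cc1N(C)CCN(C)C` gives 1460 nM

Compound 3 stands lowest of the three numbers, since an 8.2-fold lower number from compound 2 to compound 3 (0.91 log units; beyond the scatter) and a 10-fold lower number from compound 1 to compound 3 (1.02 log units; beyond the scatter) both lie beyond the scatter. Compound 4 `C=CC(=O)Nc1cc(Nc2ncc3ncn(-c4ccc(F)c(Cl)c4)c3n2)c(OC)cc1N(C)CCN(C)C` differs from compound 3 by 3-chloro-4-fluorophenyl in place of 4-bromophenyl on an aromatic nitrogen. Among the measured compounds shown here, no measured step covers this exact swap. For the measured compounds named here, the steps that bear on it are a 1.3-fold lower number from compound 1 to compound 2 (0.11 log units; within the scatter), within the scatter, and an 8.2-fold lower number from compound 2 to compound 3 (0.91 log units; beyond the scatter), beyond it. The entering 3-chloro-4-fluorophenyl carries a fluoro, as compound 2 does, together with a chloro, a halogen like the bromo of compound 3. Compound 4 is therefore expected to fall between compound 2 and compound 3. Compound 4 is thus expected to show a modest rise in number, a 2.7-fold higher number from compound 3 to compound 4 (0.44 log units; beyond the scatter). Compound 4 is estimated at 4000 nM in this assay, within the range 1200 nM to 13000 nM.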

Compound 4, half-maximal inhibitory concentration: 1610 nM
The estimate for compound 4 lay 2.5-fold (0.40 log units) above the measured number; the range from low to high includes it.
By their numbers in this assay, from the lowest: compounds 3 and 4 (each within the scatter of the next); then compounds 2 and 1 (each within the scatter of the next).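

In this assay, adding a chloro to the fluorophenyl ring is enough on its own to matter, giving a 7.5-fold lower number from compound 2 to compound 4 (0.87 log units; beyond the scatter). The 3-chloro-4-fluorophenyl group also gives a 9.5-fold lower number from compound 1 to compound 4 (0.98 log units; beyond the scatter), while swapping it for 4-bromophenyl gives a 1.1-fold higher number from compound 3 to compound 4 (0.04 log units; within the scatter), so these two groups cannot be told apart here and a bromo is not required for this level. Nothing available explains why these halogen patterns behave this way. Still open, from the compounds shown here alone, is how an amine or a carboxylic acid on this aryl ring would compare.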